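Series notes: cyclohexyl on the amide-type ring nitrogen

The source may report more compounds than this note shows. Statements on the series, on what has been measured and on what is new or still open speak of the compounds shown alone.

Measured in a functional assay on HCT-116 cells (Homo sapiens) for antiproliferative activity, read by MTT assay, with a stated time of 72 h (on this read-out lower numbers stand for stronger inhibition and higher numbers for weaker inhibition), so far
- Compound 1 `O=C1COc2ccc(-c3cccc(NS(=O)(=O)c4ccc(F)cc4)c3)cc2N1` gives > 40000 nM as a limit
- Compound 2 `COc1ccc(N2C(=O)COc3ccc(-c4cnc(Cl)c(NS(=O)(=O)c5ccc(F)cc5)c4)cc32)cc1` gives 30100 nM as a number
- Compound 3 `COc1ncc(-c2ccc3c(c2)N(C2CCCCC2)C(=O)CO3)cc1NS(=O)(=O)c1ccc(F)cc1` gives > 40000 nM as a limit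

Compound 1 stands at > 40000 nM in this assay and this is a limit, not a number. The set is marked by the limit of > 40000 nM in this assay, at which 2 of the 3 values shown sit, and compound 1 is one of those values, so it offers no measured starting point.

The change to compound 4 `O=C1COc2ccc(-c3cccc(NS(=O)(=O)c4ccc(F)cc4)c3)cc2N1C1CCCCC1` is cyclohexyl in place of hydrogen on an amide-type nitrogen in a ring and amounts to cyclohexyl in place of hydrogen on an amide-type nitrogen in a ring. For the measured compounds named here, no measured pair in the set isolates this change.

The expectation rests first on compound 3, which also carries cyclohexyl and reads > 40000 nM as a limit. Going by the values given here, compound 2 reads 30100 nM and is the only entry with a number, and that number is the sole sign of measurable activity here.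

In this assay no step beyond the scatter is expected in either direction, and a limit is the most likely report for compound 4. The estimated at least 1.1-fold lower number from compound 1 to compound 4 (0.05 log units; that floor lies within the scatter) is therefore expected to be small. For compound 4 the estimate is 35000 nM with an expected range from 15000 nM to 80000 nM in this read-out.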

Compound 4, half-maximal inhibitory concentration: 18300 nM
Compound 4: middle estimate off by 1.9-fold (0.28 log units), on the high side; the measured number falls inside the stated range.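

In this assay, cyclohexyl in place of hydrogen on the amide-type nitrogen in a ring gives an at least 2.1-fold lower number from compound 1 to compound 4 (0.33 log units; beyond the scatter), the only one-place comparison shown and the first sign that a group at this position can bring the read-out to a measurable number. Compound 1 gives > 40000 nM, and this is a limit. The step is therefore a floor rather than a measured size, because the starting compound sits at the limit of the assay: the limit of > 40000 nM in this assay, at which 2 of the 4 values shown sit.

As far as these compounds go, whether this gain is specific to cyclohexyl or would also appear with another group on this nitrogen remains open, and a methyl, a longer chain such as n-butyl, or a cyclohexyl carrying an amine would help separate those readings. Also open is whether the same change gives a step on the other cores shown, as compound 3 also carries cyclohexyl but differs from compound 4 in more than one place and so gives no clean comparison.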